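A Second Chloro on the Aromatic Ring

A few compounds are considered here, and "the series" means these few. Any claim that something is new, unique, unknown or untested is made for them only; others in the source may bear on it.

Compound 1 `O=C1CCC2(c3ccccc3)OCCCN12`: 37.5 mg/kg
Compound 2 `O=C1CCC2(c3ccc(Cl)cc3)OCCCN12`: 75 mg/kg

Both were measured in a functional assay on the whole organism (Central nervous system) for activation, with Mus musculus as the target; a higher number here means that more compound is needed for the effect, a lower number that less compound is needed. Compound 2 stands at the top of these two numbers, but the gap to compound 1 is small: a 2.0-fold higher number from compound 1 to compound 2 (0.30 log units; within the scatter). Compound 3 `O=C1CCC2(c3ccc(Cl)c(Cl)c3)OCCCN12` differs from compound 2 by chloro in place of hydrogen on an aromatic carbon. Within the data shown here, the only step that bears on this is the same kind of change, and it stayed within the scatter, so no shift beyond the scatter is expected in this assay, with at most a slight rise. For compound 3 the estimate is 90 mg/kg, within 40 mg/kg to 220 mg/kg. This estimate means an expected step of a 1.2-fold higher number from compound 2 to compound 3 (0.08 log units; within the scatter).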

Compound 3, dose for half-maximal effect: < 150 mg/kg
Compound 3: a limit, no number; the forecaster's own chance of this, stated with the estimate: 5%; the middle value lies beyond the limit too.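

In this assay, among these compounds, compound 3 gives < 150 mg/kg, which is a limit and not a number, so no step from compound 2 to compound 3 can be read. From the compounds shown here alone, whether the second chloro changes the dose needed, and in which direction, stays open.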